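The source may report more compounds than this note shows. Statements on the series, on what has been measured and on what is new or still open speak of the compounds shown alone.

The measured compounds in a functional assay on the whole organism (strain Swiss) with Mus musculus as the target, in the maximal electroshock model, with a stated time of 0.5 h, at a dose of 300 mg/kg by the intraperitoneal route (a higher number here means a stronger effect of the compound at the dose given, a lower number a weaker effect), are:

Compound 1, `CC(C(=O)N1CCN(c2ccc(Cl)cc2)CC1)N1C(=O)CCC1=O`, gives 100%.
Compound 2, `CC(C(=O)N1CCN(c2ccc(C(F)(F)F)cc2)CC1)N1C(=O)CCC1=O`, gives 25%.
Compound 3, `CC(C(=O)N1CCOCC1)N1C(=O)CCC1=O`, gives 0%.

Compound 1 stands highest of the three numbers in this assay. The nearest of the others is compound 2, separated by a number 75 percentage points lower from compound 1 to compound 2 (beyond the scatter), a change that lies beyond the scatter; the furthest is compound 3, whose value lies lower still than that of compound 1, also beyond the scatter.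

Compound 4, `Cc1cccc(N2CCN(C(=O)C(C)N3C(=O)CCC3=O)CC2)c1`, has not yet been measured. It differs from compound 1 in one place: 3-methylphenyl in place of 4-chlorophenyl on an amine nitrogen in a ring. Among the measured compounds shown here, only one measured step concerns a change on the aromatic ring attached to the shared core, the step from compound 1 to compound 2, in which trifluoromethyl took the place of chloro on an aromatic carbon and the number fell by a large amount. For the measured compounds named here, no measured pair shows a 3-methylphenyl group, so that step only tells that a change on this ring can lower the number strongly; it does not tell whether this particular change will do so. On these grounds compound 4 is expected to show a step of a number 40 percentage points lower from compound 1 to compound 4 (beyond the scatter), a drop of moderate size that may or may not reach beyond the scatter. The estimate for compound 4 is 60%, with a range from 20% to 100%.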

Compound 4, a percentage reported as activity, at one dose (the size of the read-out at that dose, not a potency): 50%
Beside the measured number, compound 4's estimate is 10 percentage points above it; the range from low to high includes it.
By their numbers in this assay, from the lowest: compound 3; then compound 2; then compound 4; then compound 1.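

In this assay, the step of a number 50 percentage points lower from compound 1 to compound 4 (beyond the scatter) shows that 3-methylphenyl in place of 4-chlorophenyl on the amine nitrogen in a ring costs much of the effect, yet compound 4 still gives 50%, so this change lowers the number without removing it. Read with a number 75 percentage points lower from compound 1 to compound 2 (beyond the scatter), it makes two changes on this aromatic ring that both lower the number beyond the scatter, and neither replacement reaches the level of compound 1, though this rests on only these two steps. The new step swaps the group as a whole, so it cannot separate the exchange of chloro for methyl from the different place of that group on the ring, and nothing available bears on why the number falls.

The compounds shown leave open how a plain phenyl with no further group, or a methoxy group on the same ring, would compare with compound 1. They also leave open whether a drop of this kind holds at other doses or times, since each number here is a single reading at one dose.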